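A few compounds are considered here, and "the series" means these few. Any claim that something is new, unique, unknown or untested is made for them only; others in the source may bear on it.

Measured so far:
compound 1 `CCOc1ccc(Cl)cc1C(C)NC(=O)N(C)S(=O)(=O)c1ccccc1` gives 10500 nM
compound 2 `CCOc1ccc(Br)cc1C(C)NC(=O)N(C)S(=O)(=O)c1ccccc1` gives 19800 nM

Going by the values given here, in a functional assay on thoracic aorta (Rattus norvegicus, strain Wistar), with a stated time of 15 min (on this read-out higher numbers stand for an effect only at larger amounts of compound and lower numbers for an effect already at smaller amounts), compound 1 stands with the lowest of the two numbers; its only neighbour is compound 2, and the single measured step, a 1.9-fold higher number from compound 1 to compound 2 (0.28 log units; within the scatter), lies within the scatter, so the two numbers cannot be ordered.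

Compound 3 `CCOc1ccc(Cl)cc1C(C)NC(=O)N(C)S(=O)(=O)c1ccc(C)cc1` differs from compound 1 by methyl in place of hydrogen on an aromatic carbon, a change on the phenyl that becomes 4-methylphenyl. Among the compounds with values here, no measured step bears on this change: the one step available concerns bromo in place of chloro on a different ring and was itself within the scatter. With nothing pointing either way, the expectation is a number for compound 3 close to that of compound 1, with the step of no change at the digits printed from compound 1 to compound 3 (within the scatter) estimated to stay within the scatter. The estimate for compound 3 in this assay is 10500 nM, with a range from 4000 nM to 28000 nM.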

Compound 3, half-maximal effective concentration: 12200 nM
Estimate against measurement, compound 3: 1.2-fold (0.07 log units) below; measured number inside the range.
By their numbers in this assay, from the lowest: compounds 1, 3 and 2 (each within the scatter of the next).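

Phenyl to 4-methylphenyl is the first change in the series on this ring, and in this assay the step, a 1.2-fold higher number from compound 1 to compound 3 (0.07 log units; within the scatter), lies within the scatter. A methyl at this place, para to a large group, therefore gives a number that cannot be told apart from that of compound 1, so both rings have now been changed once without a step beyond the scatter. No measurement is at hand that would account for this result.

On these data alone, it remains open whether another group at this place, such as an amine, a carboxylic acid or a longer chain, would give a step beyond the scatter. Also open, as far as these compounds go, is whether methyl in place of hydrogen gives a similar step on compound 2, the bromo analogue.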